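This account rests on a few compounds, and the source may have more. Where it says the series, first, only, none or still open, it means among the compounds named here.

In a functional assay on M21 cells (Homo sapiens) for antiproliferative activity, read by sulforhodamine B assay, with a stated time of 48 h (a lower number here means a stronger inhibitor, a higher number a weaker inhibitor), compound 1 `COc1ccccc1OS(=O)(=O)c1ccc(N2CCN(C)C2=O)cc1` gives 21000 nM, compound 2 `CN1CCN(c2ccc(S(=O)(=O)Oc3cccc(Cl)c3)cc2)C1=O` gives 1600 nM and compound 3 `CCN1CCN(c2ccc(S(=O)(=O)Oc3cccc(Cl)c3)cc2)C1=O` gives 3900 nM, the second highest of the three numbers. Next is compound 4 `CCN1CCN(c2ccc(S(=O)(=O)Oc3ccc(OC)cc3)cc2)C1=O`, with 4-methoxyphenyl in place of 3-chlorophenyl on an oxygen. The only methoxyphenyl so far sits on compound 1, as 2-methoxyphenyl rather than 4-methoxyphenyl. Within the data shown here, the matching change of aryl group gave a 13-fold lower number from compound 1 to compound 2 (1.12 log units; beyond the scatter), the closest precedent. The other measured step, a 2.4-fold higher number from compound 2 to compound 3 (0.39 log units; beyond the scatter), lies elsewhere on the core and bears only weakly. Only part of the large step is expected to carry over, as a modest move towards a higher number. The expected step is a 1.8-fold higher number from compound 3 to compound 4 (0.25 log units; within the scatter). Compound 4 is estimated at 7000 nM, with an expected range from 2000 nM to 25000 nM.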

Compound 4, half-maximal inhibitory concentration: 26000 nM
For compound 4 the middle estimate is 3.7-fold (0.57 log units) below the measured one; measured number above the stated range.
By their numbers in this assay, from the lowest: compound 2; then compound 3; then compounds 1 and 4 (each within the scatter of the next).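

With the rest of compound 3 unchanged, replacing the aryl group on the oxygen bound to the sulfonyl sulfur gives a 6.7-fold higher number from compound 3 to compound 4 (0.82 log units; beyond the scatter) in this assay. Alongside a 13-fold lower number from compound 1 to compound 2 (1.12 log units; beyond the scatter), 3-chlorophenyl now carries the lower number in both pairs, against 2-methoxyphenyl in one and 4-methoxyphenyl in the other. No measurement here explains this difference.

The compounds shown leave open whether the chlorine or its place on the ring governs the number. A 4-chlorophenyl or 3-methoxyphenyl on this oxygen would separate the two.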